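The source may report more compounds than this note shows. Statements on the series, on what has been measured and on what is new or still open speak of the compounds shown alone.

In a functional assay on NCI-H23 cells (Homo sapiens) for inhibition; on this read-out higher numbers stand for weaker inhibition of growth and lower numbers for stronger inhibition of growth:
- Compound 1 `COc1ccc(-n2cnnc2-c2cc(OC)c(OC)c(OC)c2)cc1`: 3160 nM
- Compound 2 `COc1ccc(-n2cnnc2-c2cc(OC)c(OC)c(OC)c2)cc1O`: 4270 nM
- Compound 3 `COc1ccc(-n2cnnc2-c2cc(OC)c(OC)c(OC)c2)cc1F`: not yet measured

Within the data shown here, only two numbers are available so far, and compound 2 cannot be ranked against compound 1, since the measured step is a 1.4-fold higher number from compound 1 to compound 2 (0.13 log units; within the scatter). Compound 3 keeps the shared core and exchanges one group, fluoro in place of hydroxy on an aromatic carbon. Among the measured compounds shown here, no fluoro compound has been measured, so the only guide is the step at this same carbon, where hydroxy replaced hydrogen. That step, a 1.4-fold higher number from compound 1 to compound 2 (0.13 log units; within the scatter), stayed within the usual scatter, so this carbon has so far shown little response in this assay. On that basis, no step beyond the scatter is expected here. The expected change is a 1.2-fold lower number from compound 2 to compound 3 (0.09 log units; within the scatter). Compound 3 is estimated at 3500 nM, with an expected range from 1300 nM to 9000 nM.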

Compound 3, concentration for 50% growth inhibition: 2240 nM
Compound 3: middle estimate off by 1.6-fold (0.19 log units), on the high side; the range from low to high includes it.
By their numbers in this assay, from the lowest: compounds 3, 1 and 2 (each within the scatter of the next).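

At this aromatic carbon, fluoro gives a 1.9-fold lower number from compound 2 to compound 3 (0.28 log units; within the scatter) when it replaces hydroxy and a 1.4-fold lower number from compound 1 to compound 3 (0.15 log units; within the scatter) when it replaces hydrogen in this assay so hydrogen, hydroxy and fluoro cannot be told apart here. Hydroxy brings a hydrogen-bond donor and a hydrogen-bond acceptor while fluoro brings neither, yet this difference between the two groups produces no step beyond the scatter. Nothing available explains why these steps are small.

On these data alone, whether an amine, a carboxylic acid or a longer chain at this carbon would move the number beyond the scatter remains open. Also open, as far as these compounds go, is how much the methoxy groups elsewhere on the shared core matter, since they are the same in all three compounds.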